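The source may report more compounds than this note shows. Statements on the series, on what has been measured and on what is new or still open speak of the compounds shown alone.

Measured so far:
compound 1 `COc1ccc(C2=C(c3cc(OC)c(OC)c(OC)c3)C(=O)C(OC(C)=O)C2)cc1`: < 1 ug/mL
compound 2 `COc1ccc(C2=C(c3cc(OC)c(OC)c(OC)c3)C(=O)C(O)C2)cc1`: < 1 ug/mL
compound 3 `COc1cc(C2=C(c3cc(C)c(OC)c(C)c3)C(O)CC2=O)cc(OC)c1OC`: > 100 ug/mL

In an ADME assay on MIA PaCa-2 cells (Homo sapiens) for cytotoxicity, read by MTT assay, with a stated time of 72 h (on this read-out higher numbers stand for weaker inhibition and lower numbers for stronger inhibition), compound 1 reaches only a limit of the assay, < 1 ug/mL. Compound 2 likewise reaches only a limit in this assay, < 1 ug/mL. Compound 3 sits at a limit of the other kind in this assay, > 100 ug/mL. The change from compound 2 to compound 1 is acetyl in place of hydrogen on an oxygen on a saturated carbon, and the step it made is a step that the two limits leave unreadable from compound 2 to compound 1; two values at the limit described by the limit of < 1 ug/mL in this assay, at which 2 of the 3 values shown sit, leave its size open.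

Compound 4 `COc1cc(C2=C(c3cc(C)c(OC)c(C)c3)C(OC(C)=O)CC2=O)cc(OC)c1OC` is not yet measured. It differs from compound 3 by acetyl in place of hydrogen on an oxygen on a saturated carbon, the same change as that from compound 2 to compound 1, at the same place. How the core of compound 3 differs from that of compound 2 is not broken down here.

Nothing measured shows what the acetyl does in this assay, and compound 3 stands only at the limit described by the limit of > 100 ug/mL in this assay, at which 1 of the 3 values shown sits. The step from compound 3 to compound 4 is expected to be a number no higher from compound 3 to compound 4 (the limit leaves the size open), resting on compound 3 at > 100 ug/mL and on the unreadable earlier step. Compound 4 is therefore estimated at 100 ug/mL, within 20 ug/mL to 300 ug/mL, and likely again only a limit.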

Compound 4, half-maximal inhibitory concentration: > 100 ug/mL
Compound 4: a limit, no number; the forecaster's own chance of this, stated with the estimate: 65%; the middle value sits exactly at the limit.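

In this assay compound 4 gives > 100 ug/mL, a limit and not a number. Compound 3 gives > 100 ug/mL, also a limit, so no step can be read between compound 3 and compound 4. The compounds shown leave open what acetyl in place of hydrogen does in this assay, in the core of compound 2 or the core of compound 3.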